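The source may report more compounds than this note shows. Statements on the series, on what has been measured and on what is new or still open speak of the compounds shown alone.

Measured compounds:
- compound 1, `CC/C(=C(/c1ccc(/C=C/C(=O)O)cc1)c1cc2ccccc2[nH]1)c1ccccc1C#N`, 9 nM
- compound 2, `CC/C(=C(/c1ccc(/C=C/C(=O)O)cc1)c1cc2ccccc2[nH]1)c1ccc(Cl)cc1`, 343 nM
- compound 3, `CC/C(=C(/c1ccc(/C=C/C(=O)O)cc1)c1cc2ccccc2[nH]1)c1ccc(Cl)cc1C(F)(F)F`, 4 nM

In a functional assay on MCF7 cells (Homo sapiens) for inhibition (a higher number here means a weaker inhibitor, a lower number a stronger inhibitor), compound 3 gives 4 nM, the lowest of the three numbers; compound 1 comes nearest, a 2.3-fold lower number from compound 1 to compound 3 (0.35 log units; beyond the scatter), and compound 2 lies furthest, an 86-fold lower number from compound 2 to compound 3 (1.93 log units; beyond the scatter). Compound 4, `CC/C(=C(/c1ccc(/C=C/C(=O)O)cc1)c1cc2ccccc2[nH]1)c1cc(Cl)ccc1Cl`, has not yet been measured in this assay. It differs from compound 3 in one place: 2,5-dichlorophenyl in place of 4-chloro-2-(trifluoromethyl)phenyl on a double-bonded chain carbon bound to a double-bonded chain carbon and a saturated chain carbon.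

Among the measured compounds shown here, two measured steps bear on this change. The step of an 86-fold lower number from compound 2 to compound 3 (1.93 log units; beyond the scatter) shows that adding a trifluoromethyl to a 4-chlorophenyl made a large difference, and the step of a 38-fold higher number from compound 1 to compound 2 (1.58 log units; beyond the scatter) shows that a 2-cyanophenyl and a 4-chlorophenyl sit far apart. For the measured compounds named here, compound 4 keeps two chlorines on its phenyl but loses the trifluoromethyl, so a loss relative to compound 3 seems more likely than a gain, though the 2,5-dichlorophenyl has no exact precedent among the three measured compounds. Compound 4 is therefore expected to give 12 nM in this assay, within a range of 3 nM to 50 nM, which means an expected step of a 3.0-fold higher number from compound 3 to compound 4 (0.48 log units; beyond the scatter).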

Compound 4, half-maximal inhibitory concentration: 71 nM
Beside the measured number, compound 4's estimate is 5.9-fold (0.77 log units) below it, outside the stated range (above it).
By their numbers in this assay, from the lowest: compound 3; then compound 1; then compound 4; then compound 2.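

In this assay the 2,5-dichlorophenyl lands at an intermediate level at this position: a 4.8-fold lower number from compound 2 to compound 4 (0.68 log units; beyond the scatter) shows a gain over the 4-chlorophenyl, while an 18-fold higher number from compound 3 to compound 4 (1.25 log units; beyond the scatter) and a 7.9-fold higher number from compound 1 to compound 4 (0.90 log units; beyond the scatter) show that it falls short of both the 4-chloro-2-(trifluoromethyl)phenyl and the 2-cyanophenyl. Two substituents on the phenyl are therefore not enough to reach the level of compound 3, and the gain from the 4-chlorophenyl is much smaller here than in an 86-fold lower number from compound 2 to compound 3 (1.93 log units; beyond the scatter). No measurement available here accounts for these differences.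

The compounds shown leave open whether a phenyl carrying only a trifluoromethyl would match compound 3. They also leave open how a methoxy or an amine would compare in place of that trifluoromethyl.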